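A few compounds are considered here, and "the series" means these few. Any claim that something is new, unique, unknown or untested is made for them only; others in the source may bear on it.

Four coumarin-bearing piperazines are compared here, three of them already measured. Compound 1 `COc1cccc(N2CCN(CC(O)COc3cc(=O)oc4ccccc34)CC2)c1` and compound 2 `COc1ccc(N2CCN(CC(O)COc3cc(=O)oc4ccccc34)CC2)cc1` share a hydroxypropyl linker, while compound 3 `COc1cccc(N2CCN(C(=O)COc3cc(=O)oc4ccccc34)CC2)c1` and the unmeasured compound 4 `COc1ccc(N2CCN(C(=O)COc3cc(=O)oc4ccccc34)CC2)cc1` carry a carbonyl-containing linker instead; the difference between the two cores is not broken down here.

In a functional assay on cells (Macrophage, Homo sapiens) for cytotoxicity, read by MTT assay, with a stated time of 24 h (a higher number here means a weaker inhibitor, a lower number a stronger inhibitor), compound 1 gives 178000 nM, and compound 2 gives 198000 nM. The change between them, (4-methoxyphenyl in place of 3-methoxyphenyl on an amine nitrogen in a ring), produced a 1.1-fold higher number from compound 1 to compound 2 (0.05 log units; within the scatter), a step that cannot be told apart from repeat measurements of one compound. Compound 3 gives 141000 nM in this assay; its values and those of compound 1 and compound 2 all lie within the scatter of one another, so no order among them can be claimed.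

Compound 4 is reached from compound 3 by the same change, (4-methoxyphenyl in place of 3-methoxyphenyl on an amine nitrogen in a ring). For the measured compounds named here, since the only precedent, compound 1 to compound 2, gave a 1.1-fold higher number from compound 1 to compound 2 (0.05 log units; within the scatter), a similarly small step is expected, a 1.1-fold higher number from compound 3 to compound 4 (0.04 log units; within the scatter). Compound 4 is therefore estimated at 155000 nM in this assay, with a range from 90000 nM to 270000 nM.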

Compound 4, half-maximal inhibitory concentration: 192000 nM
Estimate against measurement, compound 4: 1.2-fold (0.09 log units) below, and the stated range covers the measured number.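

In this assay, the swap of 4-methoxyphenyl for 3-methoxyphenyl on the carbonyl-containing core gives a 1.4-fold higher number from compound 3 to compound 4 (0.13 log units; within the scatter), and the comparison with the same swap on the hydroxypropyl core reads: the same change on two cores in this assay, a 1.1-fold higher number (0.05 log units; within the scatter) from compound 1 to compound 2 and a 1.4-fold higher number (0.13 log units; within the scatter) from compound 3 to compound 4, 1.2-fold (0.09 log units) apart, within the scatter of two such steps This shows that, across these two pairs, the swap carries from one core to the other without any difference that can be told from repeat measurements, and that neither step on its own can be told from such repeats. It does not show that the two cores respond identically, since steps this small could hide a modest difference, and two pairs say nothing about how the swap would behave on any other core.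

The compounds shown leave open what a chloro group or a hydroxyl group would give in place of the methoxy group on the phenyl ring. They also leave open what a longer chain joining the piperazine to the coumarin would give in this cell read-out.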